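Swapping piperidine for dipropylamine on a tetralin side chain

The source may hold more compounds than are shown below. What is called first, only, known or untested is meant among the compounds shown, and "the series" means these compounds.

Measured compounds:
Compound 1, `c1ccc(CC2CCN(CCCCC3CCCc4ccccc43)CC2)cc1` — 30 nM
Compound 2, `c1ccc2c(c1)CCCC2CCCCN1CCCCC1` — 4.7 nM
Compound 3, `CCCN(CCC)CCCC1CCCc2ccccc21` — 6.7 nM

In an assay on isolated protein for binding affinity to Adrenergic receptor alpha-1 (Rattus norvegicus), read by radioligand binding (on this read-out higher numbers stand for weaker inhibition and lower numbers for stronger inhibition), compound 2 gives the lowest of the three numbers. Its nearest neighbour is compound 3, whose value in this assay lies within the scatter of it, so the two cannot be told apart. Going by the values given here, compound 1 stands furthest away; the only step computed here, a 6.4-fold lower number from compound 1 to compound 2 (0.81 log units; beyond the scatter), is modest but beyond the scatter.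

Compound 4, `CCCN(CCC)CCCCC1CCCc2ccccc21`, has not been measured. Compared with compound 2 the change is dipropylamino in place of piperidin-1-yl on a saturated chain carbon, four bonds along the chain from a saturated ring carbon. Among the compounds with values here, no measured step covers this exact exchange, so the step from compound 1 to compound 2 does not bear on it directly. What does inform the expectation is compound 3, which also carries a dipropylamino group and in this assay gives 6.7 nM, indistinguishable from compound 2. The ring-opened amine therefore seems to be tolerated. The expected step is a 1.3-fold higher number from compound 2 to compound 4 (0.11 log units; within the scatter). Compound 4 is estimated at 6 nM, with a likely range from 2.5 nM to 15 nM.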

Compound 4, inhibition constant: 4.7 nM
Compound 4: middle estimate off by 1.3-fold (0.11 log units), on the high side; the measured number falls inside the stated range.
By their numbers in this assay, from the lowest: compounds 2, 4 and 3 (each within the scatter of the next); then compound 1.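

In this assay, replacing the piperidin-1-yl group with dipropylamino on the same chain gives no change at the digits printed from compound 2 to compound 4 (within the scatter). Compound 3 had already shown that dipropylamino can go with a low number, but its chain differs from that of compound 2, and this pair is the first to compare the two amines with nothing else changed. At this position, then, the closed piperidine ring is not required for a low number, and the open dipropylamino group, which has no ring, serves equally well in this assay. No accompanying evidence explains why the two amines match.

Going by these compounds, only these two amines can be compared on this chain, so it remains open whether a smaller dimethylamino group or a morpholin-4-yl ring, which has a second hetero atom, would also fit. On these data alone, it is equally open whether the match between the two amines would hold on a longer chain, or at any receptor other than this one.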